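A few compounds are considered here, and "the series" means these few. Any claim that something is new, unique, unknown or untested is made for them only; others in the source may bear on it.

Measured in an ADME assay on microsomes from liver (Mus musculus) for metabolic stability, read by mass spectrometry, with a stated time of 40 min, tested at 1 uM; a higher number here means that more of the compound is left, a lower number that less of the compound is left:
- compound 1 `COc1cc(N2CCN(Cc3ccccn3)CC2)ccc1Nc1nc(NC2CCCCC2)c2nc[nH]c2n1`: 38%
- compound 2 `COc1cc(N2CCC(CC(=O)N3CCN(C)CC3)CC2)ccc1Nc1nc(NC2CCCCC2)c2nc[nH]c2n1`: 43%

Compound 2 stands within the scatter of compound 1, so these two values cannot be told apart. Next is compound 3 `COc1cc(N2CCC(C(=O)N3CC(O)C3)CC2)ccc1Nc1nc(NC2CCCCC2)c2nc[nH]c2n1`, not yet measured in this assay. Relative to compound 2, (3-hydroxyazetidin-1-yl)carbonyl stands in place of ((4-methylpiperazin-1-yl)carbonyl)methyl on a saturated ring carbon ((3-hydroxyazetidin-1-yl)carbonyl in place of ((4-methylpiperazin-1-yl)carbonyl)methyl on a saturated ring carbon). Going by the values given here, no measured pair isolates a change at one place, so the data give no direct size for this step. The estimate therefore starts from compound 2 at 43%, and a modest rise is expected, with no change beyond the scatter remaining possible. The expected change is a number 11 percentage points higher from compound 2 to compound 3 (beyond the scatter). For compound 3, the estimated value is 54%, with an expected range from 34% to 76%.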

Compound 3, percent of the compound remaining: 65%
The estimate for compound 3 lay 11 percentage points below the measured number, within the range that was stated.
By their numbers in this assay, from the lowest: compounds 1 and 2 (each within the scatter of the next); then compound 3.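

In this assay the substituent on the saturated ring carbon, three ring bonds from the ring nitrogen, is shown to move the read-out, with a number 22 percentage points higher from compound 2 to compound 3 (beyond the scatter) as the first step in the series that can be read at one place. The change is a bundle: (3-hydroxyazetidin-1-yl)carbonyl differs from ((4-methylpiperazin-1-yl)carbonyl)methyl at once in ring size, in heavy-atom count, in the methylene link to the carbonyl and in carrying a hydrogen-bond donor. Nothing available here accounts for the step.

The compounds shown do not separate these differences, so the part each one plays stays open. Also open, on these data alone, is how an unsubstituted azetidine amide, a 3-hydroxypyrrolidine amide or a carboxylic acid on the same ring carbon would read.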